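This account rests on a few compounds, and the source may have more. Where it says the series, first, only, none or still open, it means among the compounds named here.

Compound 3 `C=CCn1c(=O)/c(=C\c2cc(Br)ccc2F)[nH]c(=O)/c1=C\c1ccccc1OC` stands outside the measured range in a functional assay on A549 cells (Homo sapiens) for cytotoxicity, read by CCK-8 assay, with a stated time of 72 h; a lower number here means a stronger inhibitor, a higher number a weaker inhibitor: for compound 3 only "not active" (no number reported) is reported, without a number. Two measured relatives set the scale. In this assay, among the measured compounds shown here, compound 1 `C=CCn1c(=O)/c(=C\c2cccc(Cl)c2)[nH]c(=O)/c1=C\c1ccccc1OC` gives 5200 nM, and compound 2 `C=CCn1c(=O)/c(=C\c2cccc(Cl)c2Cl)[nH]c(=O)/c1=C\c1ccccc1OC` gives 2300 nM; the single measured step, a 2.3-fold lower number from compound 1 to compound 2 (0.35 log units; beyond the scatter), came from a chloro in place of hydrogen on an aromatic carbon. Compound 4 `C=CCn1c(=O)/c(=C\c2cccc(Br)c2)[nH]c(=O)/c1=C\c1ccccc1OC` arises from compound 3 by hydrogen in place of fluoro on an aromatic carbon. For the measured compounds named here, no measured step removes a halogen, so the change itself offers no direct guide, and compound 3 gives no number to step from; compound 4 instead sits close to compound 1 in structure. Compound 4 is therefore expected near 6000 nM, within 2000 nM to 20000 nM, because compound 1 gives 5200 nM.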

Compound 4, half-maximal inhibitory concentration: 5400 nM
Beside the measured number, compound 4's estimate is 1.1-fold (0.05 log units) above it; low and high end bracket the measured number.
By their numbers in this assay, from the lowest: compound 2; then compounds 1 and 4 (each within the scatter of the next).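

In this assay, the step of a 1.0-fold higher number from compound 1 to compound 4 (0.02 log units; within the scatter) shows that bromo in place of chloro on this aromatic carbon leaves the reading unchanged, while a 2.3-fold higher number from compound 2 to compound 4 (0.37 log units; beyond the scatter) shows that 3-bromophenyl does not match 2,3-dichlorophenyl. Compound 4, without the fluoro of compound 3, gives a number, but the size of that change cannot be read, as compound 3 has none. Nothing measured here explains these differences. Still open, as far as these compounds go, is whether an amine or a carboxylic acid in place of the fluoro would give a number, and whether fluoro alone, without bromo, would.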